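A few compounds are considered here, and "the series" means these few. Any claim that something is new, unique, unknown or untested is made for them only; others in the source may bear on it.

Working notes on the series. In a functional assay on the whole organism with Rattus norvegicus as the target (a higher number here means that more compound is needed for the effect, a lower number that less compound is needed), compound 1 (`COc1ccccc1-c1ncc(-c2nn[nH]n2)c(O)n1`) gives 0.1 mg/kg, and compound 2 (`CCCOc1ccccc1-c1ncc(-c2nn[nH]n2)c(O)n1`) gives 0.04 mg/kg, the lower of the two numbers. For the measured compounds named here, the only measured step, a 2.5-fold lower number from compound 1 to compound 2 (0.40 log units; beyond the scatter), is modest and lies on the chain bound to the oxygen. Compound 3 (`CCCOc1ccc(N(C)C)cc1-c1ncc(-c2nn[nH]n2)c(O)n1`) keeps the propoxy group and carries dimethylamino in place of hydrogen on an aromatic carbon. Going by the values given here, no measured step bears directly on this change, so no step beyond the scatter is expected in this assay. For compound 3 the estimated value is 0.06 mg/kg, with an expected range of 0.015 mg/kg to 0.25 mg/kg. The expected change is a 1.5-fold higher number from compound 2 to compound 3 (0.18 log units; within the scatter).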

Compound 3, dose for 50% inhibition: 0.4 mg/kg
For compound 3 the middle estimate is 6.7-fold (0.82 log units) below the measured one; the measured number lies above the stated range.
By their numbers in this assay, from the lowest: compound 2; then compound 1; then compound 3.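

In this assay, for the compounds shown here, the first change on an aromatic carbon, para to a propoxy group and meta to a large group, raises the number (a 10-fold higher number from compound 2 to compound 3 (1.00 log units; beyond the scatter)). The position therefore tolerates dimethylamino less well than the chain bound to the oxygen tolerated its change, which lowered the number. Nothing available explains this rise.

The compounds shown leave open whether a primary amine, a methoxy group or a fluorine on this carbon would raise the number as well. They also leave open whether dimethylamino has the same effect with a methoxy group in place of propoxy.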